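Amine substituent changes on the shared core: pyridinylmethyl to cyclopentylmethyl

A few compounds are considered here, and "the series" means these few. Any claim that something is new, unique, unknown or untested is made for them only; others in the source may bear on it.

Measured compounds:
compound 1, `COc1cccc(-c2c(C)n(Cc3ccccc3F)c3nc(C(C)(C)C)c(CN(C)C)n3c2=O)c1`, 1700 nM
compound 2, `COc1cccc(-c2c(C)n(Cc3ccccc3F)c3nc(C(C)(C)C)c(CNCc4ccccn4)n3c2=O)c1`, 30 nM

In an assay on isolated protein for binding affinity to Gonadotropin-releasing hormone receptor (Homo sapiens) (a higher number here means a weaker inhibitor, a lower number a stronger inhibitor), compound 1 gives 1700 nM and compound 2 gives 30 nM. Going by the values given here, the step of a 57-fold lower number from compound 1 to compound 2 (1.75 log units; beyond the scatter) is the only measured step, and compound 2 holds the lowest of the two numbers, with compound 1 as its nearest neighbour at a number beyond the scatter above it.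

Compound 3, `COc1cccc(-c2c(C)n(Cc3ccccc3F)c3nc(C(C)(C)C)c(CNCC4CCCC4)n3c2=O)c1`, differs from compound 2 by the change (cyclopentyl in place of pyridin-2-yl on a saturated chain carbon bound to an amine nitrogen). Among the compounds with values here, the step from compound 1 to compound 2 shows that what sits on the amine nitrogen matters strongly, but no measured pair separates the pyridin-2-yl group itself from the rest of that substituent. With the ring nitrogen removed, some loss relative to compound 2 is expected, though smaller than the gain seen between compound 1 and compound 2. On this basis the expected step is a 5.0-fold higher number from compound 2 to compound 3 (0.70 log units; beyond the scatter). For compound 3 the estimate in this assay is 150 nM, with a range from 40 nM to 600 nM.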

Compound 3, inhibition constant: 6400 nM
Estimate against measurement, compound 3: 43-fold (1.63 log units) below; the measured number lies above the stated range.
By their numbers in this assay, from the lowest: compound 2; then compound 1; then compound 3.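

In this assay, the result shows that replacing dimethylamino does not in itself lower the number: the pyridin-2-yl group matters, as cyclopentyl in its place gives a 210-fold higher number from compound 2 to compound 3 (2.33 log units; beyond the scatter). Against the dimethylamino compound, (cyclopentylmethyl)amino gives a 3.8-fold higher number from compound 1 to compound 3 (0.58 log units; beyond the scatter), so this replacement moves the number in the opposite direction to ((pyridin-2-yl)methyl)amino. No supporting data on hand bear on why these substituents differ so widely.

The step from compound 2 to compound 3 changes ring size, aromatic character and the ring nitrogen together, so the contribution of each remains unresolved. Phenyl on the same chain carbon would separate the aromatic ring from its nitrogen, and pyridin-3-yl would show whether the location of that nitrogen matters.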